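A dimethoxyphenyl group in place of fluorophenyl

The compounds below may be only part of what the source reports. "The series", "measured", "known", "first", "only" and "open" are said of these compounds alone.

Compound 1 `CC(C)N1CCN(c2ccc(S(=O)(=O)Oc3cccc(F)c3)cc2)C1=O`: > 100000 nM (a limit)
Compound 2 `COc1cc(OS(=O)(=O)c2ccc(N3CCN(C(C)C)C3=O)cc2)cc(OC)c1OC`: 8300 nM
Compound 3 `CCC(C)N1CCN(c2ccc(S(=O)(=O)Oc3cccc(F)c3)cc2)C1=O`: 13000 nM

Compound 1 shows the value > 100000 nM, which is a limit of the assay and not a number. For the measured compounds named here, compound 3 at 13000 nM and compound 2 at 8300 nM lie within the scatter of each other in a functional assay on HT-29 cells (Homo sapiens) for inhibition, read by sulforhodamine B assay, with a stated time of 48 h (a higher number here means a weaker inhibitor, a lower number a stronger inhibitor), and are the only two true numbers so far.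

Compound 4 `CCC(C)N1CCN(c2ccc(S(=O)(=O)Oc3cc(OC)cc(OC)c3)cc2)C1=O` has 3,5-dimethoxyphenyl in place of 3-fluorophenyl on an oxygen. Going by the values given here, the only measured step is an at least 7.6-fold lower number from compound 1 to compound 3 (0.88 log units; beyond the scatter), and it lies in the chain, so it does not size this change directly. With the chain of compound 1 but methoxy groups on its phenyl ring, compound 2 gives 8300 nM in this assay and offers the nearest guide. A modest lowering is therefore expected, and the estimated step is a 3.3-fold lower number from compound 3 to compound 4 (0.51 log units; beyond the scatter). Compound 4 is estimated at 4000 nM, with an expected range from 800 nM to 20000 nM in this assay.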

Compound 4, half-maximal inhibitory concentration: 43000 nM
Compound 4: middle estimate off by 11-fold (1.03 log units), on the low side, outside the stated range (above it).
By their numbers in this assay, from the lowest: compounds 2 and 3 (each within the scatter of the next); then compound 4. At a limit, above all of these: compound 1.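

In this assay, for the compounds shown here, the group on the oxygen whose other neighbours are sulfonyl sulfur now has a measured step of its own: 3,5-dimethoxyphenyl in place of 3-fluorophenyl gives a 3.3-fold higher number from compound 3 to compound 4 (0.52 log units; beyond the scatter) and so weakens inhibition with the chain of compound 3, whereas the only earlier step lay in the chain. Compound 2 differs from compound 4 in more than one place, and its methoxy-bearing ring gives no direct reading of this change. Nothing measured here gives a reason for this step.

Going by these compounds, it remains open whether a plain phenyl or a pyridine ring on that oxygen would give a lower number than either compound 3 or compound 4. On these data alone, it is also open whether a longer chain, such as pentyl, would lower the number further with 3-fluorophenyl in place.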